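Adding Four More Fluorines to the Benzyl Group

The compounds below may be only part of what the source reports. "The series", "measured", "known", "first", "only" and "open" are said of these compounds alone.

Compound 2 `CC(=O)N[C@H]1[C@H]([C@@H](O)[C@H](O)CNC(=O)c2ccc(Cl)cc2)O[C@@](OCc2ccc(F)cc2)(C(=O)O)C[C@@H]1O` is one of two close relatives that have been tested in an in vitro assay on cells for binding affinity to myelin-associated glycoprotein (Mus musculus), read by surface plasmon resonance; on this read-out lower numbers stand for tighter binding and higher numbers for weaker binding. In this assay compound 2 gives 13000 nM, while compound 1 `CC(=O)N[C@H]1[C@H]([C@@H](O)[C@H](O)CNC(=O)c2ccc(Cl)cc2)O[C@@](OCc2ccccc2)(C(=O)O)C[C@@H]1O` gives 17000 nM; the two numbers lie within the usual scatter of each other, so neither can be called the tighter binder. Within the data shown here, the step of a 1.3-fold lower number from compound 1 to compound 2 (0.12 log units; within the scatter) is the only measured change, and it is too small to count as a real effect.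

Compound 3 `CC(=O)N[C@H]1[C@H]([C@@H](O)[C@H](O)CNC(=O)c2ccc(Cl)cc2)O[C@@](OCc2c(F)c(F)c(F)c(F)c2F)(C(=O)O)C[C@@H]1O` has not yet been measured. It differs from compound 2 by 2,3,4,5,6-pentafluorophenyl in place of 4-fluorophenyl on a saturated chain carbon bound to an oxygen on a saturated carbon. Among the measured compounds shown here, the one measured step touches on this change, since it also concerns fluorine on the same aromatic ring, but it covers only a single fluorine and stayed within the scatter. Nothing measured shows what four further fluorines do, so the expectation is a small step or none beyond the scatter. Compound 3 is therefore estimated at 11000 nM, with a range of 4000 nM to 30000 nM, which would mean an expected step of a 1.2-fold lower number from compound 2 to compound 3 (0.07 log units; within the scatter).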

Compound 3, dissociation constant: 6100 nM
The estimate for compound 3 lay 1.8-fold (0.26 log units) above the measured number; low and high end bracket the measured number.
By their numbers in this assay, from the lowest: compound 3; then compounds 2 and 1 (each within the scatter of the next).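

In this assay the change from 4-fluorobenzyl to 2,3,4,5,6-pentafluorobenzyl gives a 2.1-fold lower number from compound 2 to compound 3 (0.33 log units; beyond the scatter) and so moves the number beyond the scatter, which the single fluorine of the earlier step, a 1.3-fold lower number from compound 1 to compound 2 (0.12 log units; within the scatter), did not do. Set against the plain phenyl ring of compound 1, the same ring gives a 2.8-fold lower number from compound 1 to compound 3 (0.45 log units; beyond the scatter) and compound 3 stands apart from both relatives, while compounds 1 and 2 cannot be told apart, so this position does respond to a change in its aromatic ring, though only modestly in these three compounds. Nothing available explains the lower number.

From the compounds shown here alone, it remains open whether all five fluorines are needed or whether a ring with two or three fluorines, placed in particular ways, would show the same step. Going by these compounds, it is equally open whether the step belongs to fluorine itself, which a ring carrying chlorine, trifluoromethyl, nitrile or methoxy groups on this benzyl group could help to settle.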